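Swapping 4-Chloropyridin-3-yl for 6-Hydroxypyridin-3-yl

The compounds below may be only part of what the source reports. "The series", "measured", "known", "first", "only" and "open" are said of these compounds alone.

In an ADME assay on A549 cells (Homo sapiens) for cytotoxicity, read by resazurin assay, with a stated time of 48 h (on this read-out lower numbers stand for higher toxicity in this test and higher numbers for lower toxicity in this test), compound 1 `O=C(Nc1ccc(NCc2cccc(C(F)(F)F)c2)cc1Cl)c1cc(Cl)ccc1O` gives 13300 nM, compound 2 `O=C(Nc1ccc(NCc2ccc(O)cc2)cc1Cl)c1cc(Cl)ccc1O` gives 116000 nM, and compound 3 `O=C(Nc1ccc(NCc2cnccc2Cl)cc1Cl)c1cc(Cl)ccc1O` gives 126000 nM. Compound 3 thus stands with compound 2, well clear of compound 1. Compound 4 `O=C(Nc1ccc(NCc2ccc(O)nc2)cc1Cl)c1cc(Cl)ccc1O` differs from compound 3 as follows: 6-hydroxypyridin-3-yl in place of 4-chloropyridin-3-yl on a saturated chain carbon bound to a nitrogen on an aromatic ring. It carries 6-hydroxypyridin-3-yl in place of 4-chloropyridin-3-yl on a saturated chain carbon bound to a nitrogen on an aromatic ring. Replacing 3-(trifluoromethyl)phenyl gave an 8.7-fold higher number from compound 1 to compound 2 (0.94 log units; beyond the scatter) and a 9.5-fold higher number from compound 1 to compound 3 (0.98 log units; beyond the scatter), whereas the exchange closest to this one gave a 1.1-fold higher number from compound 2 to compound 3 (0.04 log units; within the scatter). No step beyond the scatter is therefore expected in this assay. The expected result is a 1.1-fold lower number from compound 3 to compound 4 (0.02 log units; within the scatter). Compound 4 is estimated at 120000 nM, within an expected range of 60000 nM to 240000 nM.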

Compound 4, half-maximal cytotoxic concentration: 98500 nM
The estimate for compound 4 lay 1.2-fold (0.09 log units) above the measured number, within the range that was stated.
By their numbers in this assay, from the lowest: compound 1; then compounds 4, 2 and 3 (each within the scatter of the next).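

Placing 6-hydroxypyridin-3-yl at this position gave a 1.3-fold lower number from compound 3 to compound 4 (0.11 log units; within the scatter) and a 1.2-fold lower number from compound 2 to compound 4 (0.07 log units; within the scatter), so a third group, with a ring nitrogen and a hydroxyl together, joins the other two in a single band of values. It also gave a 7.4-fold higher number from compound 1 to compound 4 (0.87 log units; beyond the scatter), so all three replacements of 3-(trifluoromethyl)phenyl now stand apart from compound 1 by a step beyond the scatter. Nothing measured here bears on why these groups fall together. The compounds shown leave open whether an aminomethylphenyl or a carboxylic acid-bearing phenyl on this saturated chain carbon would stay with compound 2, compound 3 and compound 4 or fall with compound 1.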